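A few compounds are considered here, and "the series" means these few. Any claim that something is new, unique, unknown or untested is made for them only; others in the source may bear on it.

Measured compounds and their values:

Compound 1, `Clc1ccc(-c2cc(-c3cccnc3)nc(-c3ccsc3)c2)o1`: 0%
Compound 2, `Clc1ccc(-c2cc(-c3ccoc3)cc(-c3cccs3)n2)cc1`: 0%
Compound 3, `Clc1ccc(-c2cc(-c3cccnc3)nc(-c3cccs3)c2)o1`: 25.8%

All three were tested in an assay on isolated protein for inhibition of DNA topoisomerase 1 (Homo sapiens), tested at 100 uM; a higher number here means a stronger effect of the compound at the concentration tested, a lower number a weaker effect. Compound 1 stands level with compound 2 at the digits shown, and together they are the lowest of the three numbers; the nearest neighbour of compound 1 is compound 2, with no change at the digits shown. Going by the values given here, the furthest is compound 3, and the only measured step between two compounds that differ in one place is a number 25.8 percentage points higher from compound 1 to compound 3 (beyond the scatter), a modest rise that came with thiophen-2-yl in place of thiophen-3-yl on an aromatic carbon.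

Compound 4, `Cc1ccc(-c2cc(-c3ccc(Cl)o3)cc(-c3ccsc3)n2)o1`, has not yet been measured. It differs from compound 1 in one place: 5-methylfuran-2-yl in place of pyridin-3-yl on an aromatic carbon. Among the compounds with values here, no measured step bears on this exchange; the one step recorded concerns a different group. With no guidance from the measured pairs, the expectation for compound 4 in this assay is a step of a number 5 percentage points higher from compound 1 to compound 4 (within the scatter), that is, no change beyond the scatter. Compound 4 is therefore estimated at 5%, with a range from 0% to 25%.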

Compound 4, a percentage reported as inhibition, at one concentration (the size of the read-out at that concentration, not a potency): 9.1%
Compound 4: middle estimate off by 4.1 percentage points, on the low side, and the stated range covers the measured number.
By their numbers in this assay, from the lowest: compounds 1, 2 and 4 (each within the scatter of the next); then compound 3.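

Going by these compounds alone, at the position next to the ring nitrogen, this assay shows a number 9.1 percentage points higher from compound 1 to compound 4 (within the scatter), the first reading of any exchange at this place. Pyridin-3-yl and 5-methylfuran-2-yl have the same count of heavy atoms but differ in ring size and hetero atom, and this change of ring does not move the read-out beyond the usual scatter. The step can therefore be read only as showing no clear effect, either gained or lost, and nothing measured here offers an explanation for the result.

Going by these compounds, it remains open whether 5-methylfuran-2-yl would give a different result alongside thiophen-2-yl, the group present in compound 3 at 25.8%, rather than alongside the thiophen-3-yl group it has here. Also unknown is whether a group of a different kind at this position, such as an aminomethyl group or a carboxylic acid, would lift this assay beyond the scatter, and a single test concentration would in any case give the size of the effect rather than a potency.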